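This account rests on a few compounds, and the source may have more. Where it says the series, first, only, none or still open, it means among the compounds named here.

Compound 1 `CC(C)(C)c1ccc2c(N)c(C#N)c(N)nc2n1` gives 14200 nM in a physicochemical assay for solubility, in phosphate buffer, with a stated time of 18 h (a higher number here means a more soluble compound, a lower number a less soluble compound), and compound 2 `N#Cc1c(N)nc2nc(C3CCC3)ncc2c1N` gives 217000 nM. Compound 3 `CC(C)(C)c1nc(-c2nccs2)c2c(N)c(C#N)c(N)nc2n1` stands apart: its result, < 1500 nM, is a limit of this assay and not a number, so its true solubility is known only to sit under that mark; this is the limit of < 1500 nM in this assay, at which 1 of the 3 values shown sits. Compound 4 `CC(C)(C)c1nc(-c2ncn[nH]2)c2c(N)c(C#N)c(N)nc2n1` differs from compound 3 in one place, (1H-1,2,4-triazol-5-yl in place of 1,3-thiazol-2-yl on an aromatic carbon). Going by the values given here, no pair of measured compounds shows what this change does, and the numbers for compound 1 and compound 2 do not speak to it. An upward step is nonetheless expected, an at least 3.3-fold higher number from compound 3 to compound 4 (0.52 log units; beyond the scatter) in this assay, with wide uncertainty since it starts from a limit. Compound 4 is estimated at 5000 nM, with a range from 1200 nM to 30000 nM.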

Compound 4, solubility: 64500 nM
Estimate against measurement, compound 4: 13-fold (1.11 log units) below; measured number outside the range, above it.
By their numbers in this assay, from the lowest: compound 1; then compound 4; then compound 2. At a limit, below all of these: compound 3.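

In this assay, 1H-1,2,4-triazol-5-yl in place of 1,3-thiazol-2-yl on this aromatic carbon gives an at least 43-fold higher number from compound 3 to compound 4 (1.63 log units; beyond the scatter), the first step read at this position. Compound 3 stands at a limit of the assay and not at a number: the limit of < 1500 nM in this assay, at which 1 of the 4 values shown sits. The two rings have the same count of heavy atoms, and the entering one carries 1 hydrogen-bond donor where the leaving one carries 0.

The compounds shown leave open whether a triazole with a methyl group on its ring nitrogen would behave alike. Going by these compounds, a pyrazole or an amide on this carbon also remains open.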